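Amide in Place of Amino Alcohol on the Pyrimidine Nitrogen

A few compounds are considered here, and "the series" means these few. Any claim that something is new, unique, unknown or untested is made for them only; others in the source may bear on it.

Measured compounds:
compound 1 `CNc1cc(Oc2c(C)cc(NC(=O)Nc3cccc(C(F)(F)F)c3)cc2C)ncn1` 25 nM
compound 2 `C[C@@H](O)CNc1cc(Oc2ccc(NC(=O)Nc3cccc(C(F)(F)F)c3)cc2)ncn1` 63 nM
compound 3 `CNc1cc(Oc2ccc(NC(=O)Nc3cccc(C(F)(F)F)c3)c(F)c2F)ncn1` 20 nM

In an assay on isolated protein for inhibition of serine/threonine-protein kinase TNNI3K (Homo sapiens) (a higher number here means a weaker inhibitor, a lower number a stronger inhibitor), compound 2 gives 63 nM, the highest of the three numbers; compound 1 with 25 nM and compound 3 with 20 nM both lie beyond the scatter below it. Compound 4 `CC(=O)Nc1cc(Oc2ccc(NC(=O)Nc3cccc(C(F)(F)F)c3)cc2)ncn1` has not yet been measured. It differs from compound 2 in one place: acetyl in place of 2-hydroxypropyl on a nitrogen on an aromatic ring. Among the compounds with values here, no measured pair shows this change, so the account rests on the three numbers alone. Compound 4 is expected to stay near compound 2 or drift to a somewhat higher number, the estimated step of a 1.6-fold higher number from compound 2 to compound 4 (0.20 log units; within the scatter) being modest. The estimate for compound 4 is 100 nM, within 30 nM to 320 nM.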

Compound 4, half-maximal inhibitory concentration: 20 nM
For compound 4 the middle estimate is 5.0-fold (0.70 log units) above the measured one; measured number below the stated range.
By their numbers in this assay, from the lowest: compounds 3, 4 and 1 (each within the scatter of the next); then compound 2.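

In this assay, acetyl in place of 2-hydroxypropyl on this nitrogen gives a 3.2-fold lower number from compound 2 to compound 4 (0.50 log units; beyond the scatter), so at this position the 2-hydroxypropyl group is not needed for the number seen with compound 2. Nor is a defined stereocentre at this place needed, since the acetyl group carries none. Nothing measured here accounts for the step. Open, going by these compounds, is whether a propionyl group, a longer acyl chain or a methyl carbamate on this nitrogen would keep the number. Also open, on these data alone, is how the acetyl group would behave on the core of compound 1 or of compound 3.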